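Swapping Trifluoromethyl for Chloro on a Shared Core

A few compounds are considered here, and "the series" means these few. Any claim that something is new, unique, unknown or untested is made for them only; others in the source may bear on it.

Three compounds share one core and differ at two places. In a functional assay on PC-3 cells (Homo sapiens) for inhibition, read by sulforhodamine B assay, with a stated time of 48 h (on this read-out higher numbers stand for weaker inhibition of growth and lower numbers for stronger inhibition of growth), compound 1 `COc1cc2nc(-c3ccc(Cl)cc3)cc(OCCCN3CCC(O)CC3)c2cc1OC` gives 2020 nM, compound 2 `COc1cc2nc(-c3ccc(Cl)cc3)cc(OCCCN3CCCC3)c2cc1OC` gives 1760 nM, and compound 3 `COc1cc2nc(-c3ccc(C(F)(F)F)cc3)cc(OCCCN3CCCCC3)c2cc1OC` gives 1340 nM. These three numbers lie within the usual scatter of one another, so compound 3 sits alongside the other two rather than apart from them. For the measured compounds named here, the only measured step, a 1.1-fold lower number from compound 1 to compound 2 (0.06 log units; within the scatter), concerns the saturated amine ring and not the aromatic substituent. Compound 4 `COc1cc2nc(-c3ccc(Cl)cc3)cc(OCCCN3CCCCC3)c2cc1OC` differs from compound 3 by chloro in place of trifluoromethyl on an aromatic carbon. Going by the values given here, no measured step bears on this change, so the step of a 1.1-fold higher number from compound 3 to compound 4 (0.05 log units; within the scatter) in this assay is expected to stay within the scatter. Compound 4 is therefore estimated at 1500 nM, with a range from 600 nM to 3800 nM.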

Compound 4, concentration for 50% growth inhibition: 1740 nM
The estimate for compound 4 lay 1.2-fold (0.06 log units) below the measured number; measured number inside the range.
By their numbers in this assay, from the lowest: compounds 3, 4, 2 and 1 (each within the scatter of the next).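

In this assay, chloro in place of trifluoromethyl on this aromatic carbon gives a 1.3-fold higher number from compound 3 to compound 4 (0.11 log units; within the scatter), so this swap does not separate the two compounds. With chloro kept, the saturated amine ring shows no separation either: piperidin-1-yl in place of pyrrolidin-1-yl gives a 1.0-fold lower number from compound 2 to compound 4 (0.00 log units; within the scatter), and hydrogen in place of hydroxy gives a 1.2-fold lower number from compound 1 to compound 4 (0.06 log units; within the scatter). Nothing available explains these results.

From the compounds shown here alone, whether a nitrile or an amine at this aromatic carbon would move the number beyond the scatter stays open. So does the effect of a longer chain leading to the amine ring.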